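The compounds below may be only part of what the source reports. "The series", "measured", "known", "first", "only" and "open" are said of these compounds alone.

Measured in a functional assay on CWR22R cells (Homo sapiens) for antiproliferative activity, read by CCK-8 assay, with a stated time of 6 days; on this read-out higher numbers stand for weaker inhibition and lower numbers for stronger inhibition:
Compound 1 `N#Cc1ccc(N2CCc3cc(-c4cccnc4)ccc32)cc1C(F)(F)F`: "not determined" (no result reported)
Compound 2 `N#Cc1ccc(N2CCc3cc(-c4cncnc4)ccc32)cc1C(F)(F)F`: "not determined" (no result reported)
Compound 3 `CCN(c1ccc(C#N)c(Cl)c1)c1cc(-n2cnc3ccccc32)ccc1C`: 3040 nM

Among the compounds with values here, compound 3 carries the only number in this set, because compound 1 and compound 2 have no reported result. Within the data shown here, its value therefore cannot be ranked against any other, and no measured step between compounds is available as a guide.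

Compound 4 `CCN(c1ccc(C#N)c(Cl)c1)c1cc(-c2ccco2)ccc1C` differs from compound 3 in one place: furan-2-yl in place of 1H-benzimidazol-1-yl on an aromatic carbon. The change sits on an aromatic carbon, para to a methyl group. The five-membered aromatic ring of furan-2-yl remains, while the six-membered aromatic ring of carbon only that 1H-benzimidazol-1-yl brought is gone.

With compound 3 at 3040 nM as the sole anchor, no step beyond the scatter is expected in either direction, though the uncertainty is wide. The expected change is a 1.0-fold lower number from compound 3 to compound 4 (0.01 log units; within the scatter), an estimate that stays within the usual scatter. In this assay compound 4 is expected at 3000 nM, with an estimated range of 900 nM to 10000 nM.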

Compound 4, half-maximal inhibitory concentration: > 30000 nM
Compound 4 ended at the assay's limit; the forecaster's own chance of this, stated with the estimate: 10%; at least 10-fold (1.00 log units) between middle value and limit.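

In this assay, the aromatic carbon para to a methyl group proves sensitive to the group it carries: furan-2-yl in place of 1H-benzimidazol-1-yl gives an at least 9.8-fold higher number from compound 3 to compound 4 (0.99 log units; beyond the scatter). Within the data shown here, this is the first readable step in the set, and it shows that weaker inhibition follows this single exchange on an otherwise unchanged compound. For compound 4 the reading is a limit of the assay and not a number: the limit of > 30000 nM in this assay, at which 1 of the 4 values shown sits.

As far as these compounds go, whether the difference rests with the six-membered aromatic ring of carbon only or with the nitrogen atoms of 1H-benzimidazol-1-yl stays open. Also open, from the compounds shown here alone, is how a simple amine, a carboxylic acid or a morpholine ring on the same aromatic carbon would compare with either group in this assay.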